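One ring swap on compound 2

This account rests on a few compounds, and the source may have more. Where it says the series, first, only, none or still open, it means among the compounds named here.

Measured so far in an in vitro ADME assay on microsomes from liver (Homo sapiens) for metabolic stability; a higher number here means faster removal of the compound, a lower number slower removal:
Compound 1 `CC(C)NC(=O)[C@H]1CC[C@@H](n2/c(=N/C(=O)c3ccccc3)[nH]c3ccc(CN4CCCCC4)cc32)CC1` gives 203 mL.min-1.g-1
Compound 2 `CC(C)NC(=O)[C@H]1CC[C@@H](n2/c(=N/C(=O)c3ccc(F)cc3)[nH]c3ccc(CN4CC(C(C)(C)O)C4)cc32)CC1` gives 105 mL.min-1.g-1
Compound 3 `CC(C)NC(=O)[C@H]1CC[C@@H](n2/c(=N/C(=O)c3ccccc3)[nH]c3ccc(CN4CCC(C(C)(C)O)CC4)cc32)CC1` gives 40 mL.min-1.g-1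

Compound 2 at 105 mL.min-1.g-1 cannot be told apart from compound 1 within the usual scatter of repeat measurements. Its number is clearly higher than that of compound 3, a gap beyond that scatter.

Compound 4 `CC(C)NC(=O)[C@H]1CC[C@@H](n2/c(=N/C(=O)c3ccc(F)cc3)[nH]c3ccc(CN4CCNC(=O)C4)cc32)CC1` has not been measured yet. It differs from compound 2 in a single place: 3-oxopiperazin-1-yl in place of 3-(1-hydroxy-1-methylethyl)azetidin-1-yl on a saturated chain carbon bound to an aromatic carbon. The rest of the molecule stays the same.

Going by the values given here, no measured pair makes this exact swap, so the evidence is indirect. Among the compounds with values here, the only measured single change is a 5.1-fold lower number from compound 1 to compound 3 (0.71 log units; beyond the scatter), a modest step beyond the scatter. That step puts 1-hydroxy-1-methylethyl in place of hydrogen on a saturated ring carbon, which shows that this part of the molecule can move the number. It does not show what a 3-oxopiperazin-1-yl group will do, and compound 4 loses the 1-hydroxy-1-methylethyl group altogether. A small shift towards slower removal in this assay is therefore expected, held with little confidence. The estimated change is a 1.6-fold lower number from compound 2 to compound 4 (0.21 log units; within the scatter) and may not exceed the scatter. For compound 4 the estimated value is 65 mL.min-1.g-1 with an expected range from 25 mL.min-1.g-1 to 150 mL.min-1.g-1.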

Compound 4, intrinsic clearance in microsomes: 194 mL.min-1.g-1
The estimate for compound 4 lay 3.0-fold (0.47 log units) below the measured number; the measured number lies above the stated range.
By their numbers in this assay, from the lowest: compound 3; then compounds 2, 4 and 1 (each within the scatter of the next).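

The swap gives a 1.8-fold higher number from compound 2 to compound 4 (0.27 log units; within the scatter) in this assay and so leaves the two compounds indistinguishable, even though the group on this saturated chain carbon bound to an aromatic carbon is exchanged whole. The earlier step, a 5.1-fold lower number from compound 1 to compound 3 (0.71 log units; beyond the scatter), showed that adding a group to this part of the molecule can move the number, whereas this pair shows that a four-membered ring with 1 hetero atom can give way to a six-membered ring with 2 hetero atoms without a change beyond the scatter. Both groups carry 1 hydrogen-bond donor and 2 hydrogen-bond acceptors with no net charge, but nothing available explains why this exchange produces no clear shift.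

From the compounds shown here alone, with only these two groups compared directly at this place, the role of the carbonyl in 3-oxopiperazin-1-yl remains unknown, and a plain piperazine or a morpholine ring on the same carbon would help to test it. Also open is how a carboxylic acid or an open-chain amine at this place would behave, since the compounds shown carry only saturated rings here.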